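Larger acyl group on the amide of compound 2

This account rests on a few compounds, and the source may have more. Where it says the series, first, only, none or still open, it means among the compounds named here.

Compound 1 `Cc1cc(C(=O)Nc2ccccc2)nn1Cc1cc(Cl)ccc1OCc1ccccc1`: 39.8 nM
Compound 2 `CC(=O)Nc1cc(C)n(Cc2cc(Cl)ccc2OCc2ccccc2)n1`: 316 nM

Among the measured compounds shown here, in an assay on CHO-K1 cells for displacement of a labelled ligand from prostaglandin E2 receptor EP1 subtype (Homo sapiens) (on this read-out lower numbers stand for stronger inhibition and higher numbers for weaker inhibition), compound 2 stands highest of the two numbers; the one step known, a 7.9-fold higher number from compound 1 to compound 2 (0.90 log units; beyond the scatter), separates it from compound 1. Compound 3 `Cc1cc(NC(=O)C(C)C)nn1Cc1cc(Cl)ccc1OCc1ccccc1` differs from compound 2 by isopropyl in place of methyl on a carbonyl carbon. For the measured compounds named here, only that single step bears on this change, and it altered the amide in a different way, so it is a loose guide at best: the larger amide substituent went with the lower number. A modest improvement is therefore expected for compound 3, a 1.6-fold lower number from compound 2 to compound 3 (0.20 log units; within the scatter), though a change within the scatter would not surprise. The estimate for compound 3 is 200 nM, ranging from 80 nM to 500 nM.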

Compound 3, half-maximal inhibitory concentration: 25.1 nM
Compound 3: middle estimate off by 8.0-fold (0.90 log units), on the high side; the measured number lies below the stated range.
By their numbers in this assay, from the lowest: compounds 3 and 1 (each within the scatter of the next); then compound 2.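

Isopropyl in place of methyl on the carbonyl carbon gives a 13-fold lower number from compound 2 to compound 3 (1.10 log units; beyond the scatter) and shows that this small group has a large effect on the number. Swapping phenylcarbamoyl for (isopropylcarbonyl)amino gives a 1.6-fold lower number from compound 1 to compound 3 (0.20 log units; within the scatter) and shows that, on the shared core, a group with no ring can match one that carries a phenyl ring. Nothing available explains why the methyl-to-isopropyl step is so large.

Still open, going by these compounds, is whether cyclopropyl, tert-butyl or a longer chain such as butyl on the same carbonyl carbon would hold this level or go beyond it. Also open, on these data alone, is how an amine in that place would fare.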